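Aryl in place of aminobutyl on ring nitrogen

The compounds below may be only part of what the source reports. "The series", "measured", "known", "first", "only" and "open" are said of these compounds alone.

Measured in an assay on CHO cells for displacement of a labelled ligand from adenosine receptor A1 (Homo sapiens), read by scintillation counting, tested at 10 uM; a higher number here means more inhibition at the concentration tested (going by the name of the read-out), a lower number less inhibition:
Compound 1, `CNC(=O)[C@@]12C[C@@H]1[C@@H](n1cnc3c(NCc4cccc(Cl)c4)nc(C#CCCCCc4cn(CCCCN)nn4)nc31)[C@H](O)[C@@H]2O`: 13%
Compound 2, `CNC(=O)[C@@]12C[C@@H]1[C@@H](n1cnc3c(NCc4cccc(Cl)c4)nc(C#CCCCCc4cn(Cc5ccc(-n6sccc6=O)cc5)nn4)nc31)[C@H](O)[C@@H]2O`: 15%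
Compound 3, `C#CCCCCC#Cc1nc(NCc2cccc(Cl)c2)c2ncn([C@H]3[C@H](O)[C@H](O)[C@]4(C(=O)NC)C[C@H]34)c2n1`: 31%

Compound 1 gives the lowest of the three numbers; compound 2 sits within the scatter of it, while compound 3 lies beyond it. Compound 4, `CNC(=O)[C@@]12C[C@@H]1[C@@H](n1cnc3c(NCc4cccc(Cl)c4)nc(C#CCCCCc4cn(-c5cccc([N+](=O)[O-])c5)nn4)nc31)[C@H](O)[C@@H]2O`, is not yet measured and differs from compound 1 thus: 3-nitrophenyl in place of 4-aminobutyl on an aromatic nitrogen. The step bearing most directly on this is a number 2 percentage points higher from compound 1 to compound 2 (within the scatter), where a larger ring-bearing group also replaced the short chain on the same aromatic nitrogen. The step of a number 18 percentage points higher from compound 1 to compound 3 (beyond the scatter) removed the whole ring-bearing substituent and is less comparable. No step beyond the scatter is therefore expected in this assay for compound 4. Compound 4 is estimated at 17%, range 5% to 30%, meaning an expected step of a number 4 percentage points higher from compound 1 to compound 4 (within the scatter).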

Compound 4, a percentage reported as inhibition, at one concentration (the size of the read-out at that concentration, not a potency): 8%
Beside the measured number, compound 4's estimate is 9 percentage points above it; low and high end bracket the measured number.
By their numbers in this assay, from the lowest: compounds 4, 1 and 2 (each within the scatter of the next); then compound 3.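

In this assay, 3-nitrophenyl in place of 4-aminobutyl on the aromatic nitrogen gives a number 5 percentage points lower from compound 1 to compound 4 (within the scatter) and so removes the amine and sets a ring directly on that nitrogen without a step beyond the scatter. With a number 2 percentage points higher from compound 1 to compound 2 (within the scatter) as well, this position has now taken two different ring-bearing groups with neither step beyond the scatter. Nothing measured here bears on the reason for this result. Going by these compounds, whether plain phenyl would read differently from 3-nitrophenyl remains open. So does whether a carboxylic acid or a longer amine-ending chain on this nitrogen would give a step beyond the scatter.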